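Swapping methoxy for methylsulfanyl on the phenyl ring

A few compounds are considered here, and "the series" means these few. Any claim that something is new, unique, unknown or untested is made for them only; others in the source may bear on it.

- compound 1 `COc1cc(C(=O)c2sc3ccccc3c2-c2ccccc2)cc(OC)c1OC` gives 1700 nM
- compound 2 `COc1cc(C(=O)c2sc3ccccc3c2-c2ccc(Cl)cc2)cc(OC)c1OC` gives 3300 nM
- compound 3 `COc1ccc(-c2c(C(=O)c3cc(OC)c(OC)c(OC)c3)sc3ccccc23)cc1` gives 1600 nM

In a functional assay on HL-60 cells (Homo sapiens) for antiproliferative activity, read by MTT assay, with a stated time of 72 h (a higher number here means a weaker inhibitor, a lower number a stronger inhibitor), compound 3 sits level with compound 1 within the scatter (a 1.1-fold lower number from compound 1 to compound 3 (0.03 log units; within the scatter)), while compound 2 has a modestly higher number (a 2.1-fold lower number from compound 2 to compound 3 (0.31 log units; beyond the scatter)). Compound 4 `COc1cc(C(=O)c2sc3ccccc3c2-c2ccc(SC)cc2)cc(OC)c1OC` carries one change (methylsulfanyl in place of methoxy on an aromatic carbon): methylsulfanyl in place of methoxy on an aromatic carbon, para to a large group. For the measured compounds named here, no measured step makes this swap. The nearest steps exchange other groups at that place (a 1.9-fold higher number from compound 1 to compound 2 (0.29 log units; within the scatter); a 2.1-fold lower number from compound 2 to compound 3 (0.31 log units; beyond the scatter)) and are small, so no step beyond the scatter is expected in this assay. The expected step is small (a 1.3-fold higher number from compound 3 to compound 4 (0.10 log units; within the scatter)). For compound 4 the estimated value is 2000 nM (range 900 nM to 4500 nM).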

Compound 4, half-maximal inhibitory concentration: 1300 nM
Compound 4: the middle estimate sits 1.5-fold (0.19 log units) above what was measured; the range from low to high includes it.
By their numbers in this assay, from the lowest: compounds 4, 3, 1 and 2 (each within the scatter of the next, the first and the last beyond it).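

In this assay, methylsulfanyl at this place gives a 1.2-fold lower number from compound 3 to compound 4 (0.09 log units; within the scatter) and so stands level with methoxy, and a 1.3-fold lower number from compound 1 to compound 4 (0.12 log units; within the scatter) shows it also level with plain hydrogen. Only chloro is separated from it, by a 2.5-fold lower number from compound 2 to compound 4 (0.40 log units; beyond the scatter) and thus a modest step beyond the scatter. No evidence here gives a reason for these numbers. Going by these compounds, what remains open is whether a larger change at this place, such as an amine or a carboxylic acid, would move the number beyond the scatter in either direction.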